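Cytotoxicity notes: swapping the amide substituent of compound 1

A few compounds are considered here, and "the series" means these few. Any claim that something is new, unique, unknown or untested is made for them only; others in the source may bear on it.

Compound 1 `CCCC(=O)OCSc1ccccc1C(=O)NC1(C(N)=O)CCCC1` gives > 100 uM in an ADME assay on CEM-SS cells (Homo sapiens) for cytotoxicity, read by XTT assay, with a stated time of 6 days; a higher number here means that more compound is tolerated, a lower number that less compound is tolerated; this is a limit of the assay, not a number. Compound 2 `CCCC(=O)OCSc1ccccc1C(=O)NCCCNC(C)=O` gives 21.1 uM in this assay.

Compound 1 thus sits at the limit of > 100 uM in this assay, at which 1 of the 2 values shown sits. Compound 3 `CCCC(=O)OCSc1ccccc1C(=O)NCC(=O)OC` differs from it in one place: (methoxycarbonyl)methyl in place of 1-carbamoylcyclopentyl on an amide-type nitrogen. Going by the values given here, the only measured step that bears on this position is an at least 4.7-fold lower number from compound 1 to compound 2 (0.67 log units; beyond the scatter), an at least modest drop. A drop of similar size is expected here, giving an at least 3.3-fold lower number from compound 1 to compound 3 (0.52 log units; beyond the scatter). Compound 3 is therefore estimated at 30 uM, within 10 uM to 100 uM.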

Compound 3, half-maximal toxic concentration: 27.3 uM
Compound 3: the middle estimate sits 1.1-fold (0.04 log units) above what was measured; the range from low to high includes it.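

In this assay, a second replacement without a ring, (methoxycarbonyl)methyl, also gives a drop, so the drop is not confined to the 3-acetamidopropyl of compound 2: an at least 3.6-fold lower number from compound 1 to compound 3 (0.56 log units; beyond the scatter). The two replacements cannot be told apart, with a 1.3-fold higher number from compound 2 to compound 3 (0.11 log units; within the scatter). The top of both drops stays open-ended, as compound 1 stands at a limit and not a number: the limit of > 100 uM in this assay, at which 1 of the 3 values shown sits.

From the compounds shown here alone, whether the ring or the carbamoyl of 1-carbamoylcyclopentyl goes with the higher tolerance stays open. Going by these compounds, how a carboxylic acid or a plain alkyl chain on the amide-type nitrogen would compare also stays open.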